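A few compounds are considered here, and "the series" means these few. Any claim that something is new, unique, unknown or untested is made for them only; others in the source may bear on it.

The measured compounds are:
compound 1 `CN(C)CCn1cnnc1-c1cc(Oc2ccc(NC(=O)N/N=C/c3ccc(O)cc3)cc2F)ccn1`, "not determined" (no result reported);
compound 2 `CN(C)CCn1cnnc1-c1cc(Oc2ccc(NC(=O)N/N=C/c3ccc(F)cc3)cc2F)ccn1`, 3980 nM;
compound 3 `COc1ccc(/C=N/NC(=O)Nc2ccc(Oc3ccnc(-c4nncn4CCN(C)C)c3)c(F)c2)cc1O`, "not determined" (no result reported).

Compound 3 stands without a single number in an ADME assay on WI-38 cells (Homo sapiens) for cytotoxicity, read by MTT assay, with a stated time of 72 h (a higher number here means a weaker inhibitor, a lower number a stronger inhibitor), and it is not alone in that: compound 1 likewise has no result there. Only compound 2 brings a number to the set, and in this assay compound 2 gives 3980 nM. Among the measured compounds shown here, no pair of compounds in the set differs in one place with a number on both sides, so no step can be read off between measured compounds.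

The step from compound 3 to compound 4 `CN(C)CCn1cnnc1-c1cc(Oc2ccc(NC(=O)N/N=C/c3ccc(Cl)cc3Cl)cc2F)ccn1` exchanges one aromatic group for another: 2,4-dichlorophenyl in place of 3-hydroxy-4-methoxyphenyl on a carbon with a double bond to nitrogen. Compound 4 is yet to be measured in this assay.

Compound 3 carries no number. The size of the step to compound 4 in this assay therefore cannot be anchored on compound 3 itself. What remains as a point of reference is compound 2, whose value of 3980 nM belongs to a close relative carrying a different halogen-bearing phenyl at the same carbon. On that basis the account expects compound 4 to lie in the same region as compound 2, without a step beyond the scatter in either direction being predictable. Compound 4 is therefore estimated at 3500 nM, with a range from 900 nM to 14000 nM.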

Compound 4, half-maximal inhibitory concentration: 4760 nM
The estimate for compound 4 lay 1.4-fold (0.13 log units) below the measured number; low and high end bracket the measured number.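

Among the compounds shown here, with compound 4 the set gains its only readable step at this carbon with a double bond to nitrogen: in this assay the exchange of 4-fluorophenyl for 2,4-dichlorophenyl gives a 1.2-fold higher number from compound 2 to compound 4 (0.08 log units; within the scatter) and so does not separate these two halogen-bearing phenyl groups. For the compounds shown here, the result therefore shows that, between this pair, a second halogen on the phenyl and a chlorine-for-fluorine exchange come together without a step beyond the scatter, though the one step cannot divide the two changes from each other. Steps from compound 1 or compound 3 to any other compound cannot be read, and nothing at hand gives a reason for the result.

The compounds shown leave open how a phenyl carrying an amine or a carboxylic acid at this carbon would compare with compound 2 and compound 4 in this assay and whether a phenyl with only one chlorine would read the same. They also leave open whether this pairing would hold with a longer chain in place of the dimethylaminoethyl group on the shared core.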